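The compounds below may be only part of what the source reports. "The series", "measured", "known", "first", "only" and "open" are said of these compounds alone.

Compound 1 `COc1cc(/C=C/C(=O)c2cccc(-n3cc(-c4ccc(Cl)cc4)[nH]c3=O)c2)cc(OC)c1OC`: 8880 nM
Compound 2 `O=C(/C=C/c1cccc(O)c1)c1cccc(-n2cc(-c3ccccc3)[nH]c2=O)c1`: 3650 nM

In a functional assay on UACC-62 cells (Homo sapiens) for inhibition (on this read-out higher numbers stand for weaker inhibition of growth and lower numbers for stronger inhibition of growth), compound 1 gives 8880 nM, the higher of the two numbers shown, while compound 2 gives 3650 nM, a gap beyond the usual scatter. Compound 3 `COc1ccc(-c2cn(-c3cccc(C(=O)/C=C/c4cc(OC)c(OC)c(OC)c4)c3)c(=O)[nH]2)cc1` has not been measured. It differs from compound 1 by methoxy in place of chloro on an aromatic carbon. Going by the values given here, no measured pair shows what this exchange does in this assay, so the expectation rests on compound 1 alone. A step of a 1.4-fold lower number from compound 1 to compound 3 (0.14 log units; within the scatter) is expected, leaning toward lower numbers but not clearly beyond the scatter. Compound 3 is estimated at 6500 nM, with a range from 2500 nM to 16000 nM.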

Compound 3, concentration for 50% growth inhibition: 2060 nM
Beside the measured number, compound 3's estimate is 3.2-fold (0.50 log units) above it; measured number below the stated range.
By their numbers in this assay, from the lowest: compounds 3 and 2 (each within the scatter of the next); then compound 1.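

In this assay, changing 4-chlorophenyl to 4-methoxyphenyl gives a 4.3-fold lower number from compound 1 to compound 3 (0.63 log units; beyond the scatter), so growth inhibition at this position, para to a large group, responds to the group placed there. This is one pair, which shows the size of a single exchange and no trend. No supporting measurement explains the change. From the compounds shown here alone, it remains open whether an amine or a carboxylic acid at this position would give a lower or a higher number. Going by these compounds, whether the same exchange has a similar effect on other compounds also remains open.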